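The source may hold more compounds than are shown below. What is called first, only, known or untested is meant among the compounds shown, and "the series" means these compounds.

In a functional assay on PA-1 cells (Homo sapiens) for cytotoxicity, read by MTT assay, with stated times of 6 h and 48 h (a higher number here means a weaker inhibitor, a lower number a stronger inhibitor), compound 1 `O=C(/C=C/c1cc(Br)c(Br)[nH]1)c1ccc[nH]1` gives a measured value of 500 nM. Compound 2 `Cn1c(-c2cc(-c3ccccc3)no2)cc(Br)c1Br` gives only a limit, >= 100000 nM. Compound 3 `Cn1c(-c2cc(-c3ccccc3O)no2)cc(Br)c1Br` also gives only a limit, >= 100000 nM, so it has no exact number. The picture so far is the limit of >= 100000 nM in this assay, at which 2 of the 3 values shown sit.

Going by the values given here, the one measured step between closely matched compounds is a step that the two limits leave unreadable from compound 2 to compound 3. It therefore provides no size to carry forward.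

Compound 4 `Oc1ccccc1-c1cc(-c2cc(Br)c(Br)[nH]2)on1` comes from compound 3 through a single change, hydrogen in place of methyl on an aromatic nitrogen. Among the compounds with values here, no measured step covers this change directly. Within the data shown here, compound 1 also has hydrogen on an aromatic nitrogen and, at 500 nM, is the only compound here with an exact number. Its structure differs from that of compound 4 in other places too, so it offers only a weak hint.

On that hint, the expected shift in this assay is towards a lower number, meaning a stronger inhibitor, though its size is very uncertain and the result may remain a limit. The estimated change is an at least 5.0-fold lower number from compound 3 to compound 4 (0.69 log units; beyond the scatter). For compound 4, the estimated value is 20000 nM, with an expected range from 2000 nM to 100000 nM.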

Compound 4, half-maximal inhibitory concentration: >= 100000 nM
Compound 4 ended at the assay's limit (the forecaster's own chance of this, stated with the estimate: 40%); at least 5.0-fold (0.69 log units) between middle value and limit.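

Compound 3 and compound 4 both give only a limit in this assay, so the step between them cannot be read. The picture remains: the limit of >= 100000 nM in this assay, at which 3 of the 4 values shown sit.

Still open, from the compounds shown here alone, is whether hydrogen in place of methyl on an aromatic nitrogen shifts the value at all, and which structural difference sets apart compound 1, at 500 nM.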